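This account rests on a few compounds, and the source may have more. Where it says the series, first, only, none or still open, it means among the compounds named here.

Measured so far in an assay on isolated protein for inhibition of protein deacetylase HDAC6 (Homo sapiens), read by fluorescence, tested at 1 uM; a higher number here means more inhibition at the concentration tested (going by the name of the read-out), a lower number less inhibition:
compound 1 `CC(C)(C)OC(=O)N[C@@H](CCCCS)C(=O)NC1CCCC1` gives 50%
compound 2 `COC(=O)CCCCC[C@H](NC(=O)OC(C)(C)C)C(=O)NC1CCCC1` gives 60%
compound 3 `CC(C)(C)OC(=O)N[C@@H](CCCCCC(=O)O)C(=O)NC1CCCC1` gives 45%

Compound 3 stands lowest of the three numbers in this assay. Its nearest neighbour is compound 1, a step within the scatter (a number 5 percentage points lower from compound 1 to compound 3 (within the scatter)); its furthest is compound 2, with a step of a number 15 percentage points lower from compound 2 to compound 3 (beyond the scatter) that lies beyond the scatter.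

Compound 4 `CC(C)(C)OC(=O)N[C@@H](CCCCCCO)C(=O)NC1CCCC1` is not yet measured. Its change from compound 3 is hydroxymethyl in place of carboxy on a saturated chain carbon, six bonds along the chain from an amide-type nitrogen and a carbonyl carbon. Going by the values given here, no measured step exchanges a carboxy group for a hydroxymethyl group. The step nearest in kind is a number 15 percentage points lower from compound 2 to compound 3 (beyond the scatter), where the number falls modestly. The two chain-end exchanges a number 10 percentage points higher from compound 1 to compound 2 (within the scatter) and a number 5 percentage points lower from compound 1 to compound 3 (within the scatter) both stay within the scatter, so differing groups at the chain end have so far moved the number little. For compound 4 a step of a number 7 percentage points higher from compound 3 to compound 4 (within the scatter) is therefore expected, small and, given that compound 3 already holds the lowest of the three numbers, upward rather than downward if anywhere. Compound 4 is estimated at 52% in this assay, with a range from 38% to 66%.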

Compound 4, a percentage reported as inhibition, at one concentration (the size of the read-out at that concentration, not a potency): 3%
Estimate against measurement, compound 4: 49 percentage points above; measured number below the stated range.
By their numbers in this assay, from the lowest: compound 4; then compounds 3, 1 and 2 (each within the scatter of the next, the first and the last beyond it).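

In this assay, hydroxymethyl in place of carboxy gives a number 42 percentage points lower from compound 3 to compound 4 (beyond the scatter) even though the computed hydrogen-bond donor and acceptor counts of the two groups are the same, so those counts do not track the number at this position. The steps of a number 57 percentage points lower from compound 2 to compound 4 (beyond the scatter) and a number 47 percentage points lower from compound 1 to compound 4 (beyond the scatter) are also large, which sets the hydroxyl-ended chain of compound 4 apart from the sulfanyl, methoxycarbonyl and carboxy ends of the other three compounds. Nothing at hand accounts for this loss.

Going by these compounds, it remains open whether the loss follows the missing carbonyl, since a primary amide or an aldehyde at the same chain end would separate that from the hydroxyl. A shorter or longer chain carrying the same hydroxyl, or an amine in its place, is also untested in these compounds.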